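Chromone series, growth inhibition on ovarian cells

The source may report more compounds than this note shows. Statements on the series, on what has been measured and on what is new or still open speak of the compounds shown alone.

Measured compounds:
compound 1 `O=c1c(C(=S)Nc2ccccc2)coc2ccccc12` — 58%
compound 2 `Cc1ccc2occ(C3N=C(c4ccccc4)SS3)c(=O)c2c1` — 54%
compound 3 `O=c1c(C(=S)Nc2ccccc2)coc2cc(Cl)c(Cl)cc12` — 2%

Three compounds have been run in a functional assay on OVCAR-3 cells (Homo sapiens) for inhibition, read by sulforhodamine B assay, with a stated time of 48 h, tested at 100 uM; a lower number here means less inhibition of growth, a higher number more inhibition of growth at the concentration tested. Compound 2 stands second highest of the three numbers; its nearest neighbour is compound 1, whose value lies within the scatter of that of compound 2, so no order between the two can be read. Compound 3 is the furthest from compound 2 and lies well beyond the scatter, with only weak growth inhibition. Compound 1 and compound 3 differ in more than one place, so their two values say only that the dichloro-bearing thioamide sits far below the unsubstituted one.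

The next compound, compound 4 `O=c1c(C2N=C(c3ccccc3)SS2)coc2ccc(Cl)cc12`, keeps the core of compound 2 and changes one substituent: chloro in place of methyl on an aromatic carbon. Among the measured compounds shown here, no step between two measured compounds isolates this change, so nothing measured bears directly on it. Given that compound 3, the only chloro-bearing compound so far, gives 2%, a downward step is expected in this assay, though a smaller one than that gap, since compound 4 carries only one chloro and a different core. Compound 4 is estimated at 35%, within 8% to 62%, which means an expected step of a number 19 percentage points lower from compound 2 to compound 4 (beyond the scatter).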

Compound 4, percent growth inhibition at one concentration: 71%
Compound 4: the middle estimate sits 36 percentage points below what was measured; the measured number lies above the stated range.
By their numbers in this assay, from the lowest: compound 3; then compounds 2 and 1 (each within the scatter of the next); then compound 4.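

Chloro in place of methyl on this aromatic carbon of the shared core gives, in this assay, a number 17 percentage points higher from compound 2 to compound 4 (beyond the scatter), the first step in the series that isolates a single substituent. Methyl is therefore not required at this position for growth inhibition at the concentration tested, and a chloro group here is compatible with a high number on this core. Nothing available explains the direction or size of this step.

On these data alone, whether other groups on this carbon, such as fluoro, methoxy, an amine or a carboxylic acid, would continue this rise or reverse it remains open. Also open, as far as these compounds go, is whether the same exchange of methyl for chloro would shift the thioamide compounds in the same direction, since this step rests on one pair with one core.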